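From fluoro to methoxy on a shared core

The source may hold more compounds than are shown below. What is called first, only, known or untested is meant among the compounds shown, and "the series" means these compounds.

Measured in a functional assay on MKN-28 cells (Homo sapiens) for cytotoxicity, read by MTT assay; a higher number here means a weaker inhibitor, a lower number a stronger inhibitor:
Compound 1 `C=C1C(=O)[C@]23C[C@@]1(Cl)CC[C@H]2[C@@]12C=CC(=O)[C@](C)(C(=O)O1)[C@H]2[C@@H]3C(=O)OC`: 4800 nM
Compound 2 `C=C1C(=O)[C@]23C[C@@]1(F)CC[C@H]2[C@@]12C=CC(=O)[C@](C)(C(=O)O1)[C@H]2[C@@H]3C(=O)OC`: 4100 nM
Compound 3 `C=C1C(=O)[C@]23C[C@@]1(F)CC[C@H]2[C@@]12C=CC(=O)[C@](C)(C(=O)O1)[C@H]2[C@@H]3C(=O)OCc1ccccc1`: 9800 nM

Compound 2 gives 4100 nM, which puts it at the low end of this small set, together with compound 1, as the two lie within the scatter of each other. Compound 3 stands apart from it, with a 2.4-fold higher number from compound 2 to compound 3 (0.38 log units; beyond the scatter). Within the data shown here, that step comes from a change elsewhere in the molecule, so it shows only that a single swap on this core can shift the number modestly.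

The next compound to be tested is compound 4 `C=C1C(=O)[C@]23C[C@@]1(OC)CC[C@H]2[C@@]12C=CC(=O)[C@](C)(C(=O)O1)[C@H]2[C@@H]3C(=O)OC`, which has methoxy in place of fluoro on a saturated ring carbon. The closest evidence is the change at that same carbon, with a 1.2-fold lower number from compound 1 to compound 2 (0.07 log units; within the scatter). That swap exchanged one halogen for another, however, and no group joined through oxygen has yet been measured at this carbon, so the guide is only partial.

In this assay, a small change is therefore expected, and it may not exceed the scatter. The estimated result is a 1.2-fold higher number from compound 2 to compound 4 (0.09 log units; within the scatter). The value expected for compound 4 is 5000 nM, with an estimated range of 2200 nM to 11000 nM.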

Compound 4, half-maximal inhibitory concentration: 3400 nM
Compound 4: the middle estimate sits 1.5-fold (0.17 log units) above what was measured; the measured number falls inside the stated range.
By their numbers in this assay, from the lowest: compounds 4, 2 and 1 (each within the scatter of the next); then compound 3.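

Methoxy is the first group joined through oxygen shown at this saturated ring carbon, and in this assay it can be set against both halogens. Methoxy in place of fluoro gives a 1.2-fold lower number from compound 2 to compound 4 (0.08 log units; within the scatter) and methoxy in place of chloro gives a 1.4-fold lower number from compound 1 to compound 4 (0.15 log units; within the scatter) so neither step can be told apart from repeat-measurement noise. The number at this carbon therefore holds across the three groups shown, even though methoxy, unlike fluoro, is counted as a hydrogen-bond acceptor, and no supporting data are at hand to explain this.

The compounds shown leave open whether a much different group at this carbon, such as an amine, a carboxylic acid or a longer chain like butoxy, would also keep the number in this range. They also leave open whether methoxy would read the same alongside the phenyl group that compound 3 carries on its ester, a change that moved the number beyond the scatter when fluoro sat at this carbon.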